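A Halogenated Aryl in Place of Methoxyphenyl

A few compounds are considered here, and "the series" means these few. Any claim that something is new, unique, unknown or untested is made for them only; others in the source may bear on it.

Compound 1 `COc1ccc(-n2ccc(=O)c(C(=O)Nc3ccc(Oc4ccnc5[nH]ccc45)c(F)c3)n2)cc1` was tested in a functional assay on A549 cells (Homo sapiens) for cytotoxicity, read by MTT assay, with a stated time of 72 h; on this read-out higher numbers stand for weaker inhibition and lower numbers for stronger inhibition. In this assay compound 1 gives > 60000 nM, which is a limit of the assay rather than a number. Compound 2 `COc1ccc(-n2ccc(=O)c(C(=O)Nc3ccc(Oc4ccnc5c4ccn5C)c(F)c3)n2)cc1` carries a methyl in place of hydrogen on an aromatic nitrogen, and in this assay compound 2 gives > 60000 nM, again a limit. The step that the two limits leave unreadable from compound 1 to compound 2 therefore cannot be read, and compound 2 stands only at the limit of > 60000 nM in this assay, at which 2 of the 2 values shown sit.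

Compound 3 `Cn1ccc2c(Oc3ccc(NC(=O)c4nn(-c5ccc(Cl)c(F)c5)ccc4=O)cc3F)ccnc21` differs from compound 2 by 4-chloro-3-fluorophenyl in place of 4-methoxyphenyl on an aromatic nitrogen. Among the measured compounds shown here, none of the measured steps bears on this change; the only measured step, from compound 1 to compound 2, concerns a different place and is itself unreadable. No direction can be taken from the shown numbers, and the change may leave the outcome at the limit once more. Compound 3 is estimated at 45000 nM, with a range from 10000 nM to 120000 nM. The step from compound 2 to compound 3 that this estimate means is an at least 1.3-fold lower number from compound 2 to compound 3 (0.12 log units; that floor lies within the scatter), expected only as a guess made against a limit.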

Compound 3, half-maximal inhibitory concentration: > 60000 nM
Compound 3: only a limit was reported (the forecaster's own chance of this, stated with the estimate: 60%); middle value at least 1.3-fold (0.12 log units) away from the limit.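

In this assay compound 3 gives > 60000 nM, which is again a limit and not a number. No new step can be read from compound 2 to compound 3: the limit of > 60000 nM in this assay, at which 3 of the 3 values shown sit.

The compounds shown leave open whether either change, on the aromatic nitrogen of the core or on the aryl group, makes any difference in this assay.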